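Triazole to hydroxy on the propyl chain of compound 1

This account rests on a few compounds, and the source may have more. Where it says the series, first, only, none or still open, it means among the compounds named here.

Measured so far:
compound 1 `Cn1cc(C2=C(c3nn(CCCn4cncn4)c4ncccc34)C(=O)NC2=O)c2ccccc21`: > 100000 nM
compound 2 `Cn1cc(C2=C(c3nn(CCCn4cncn4)c4ncccc34)C(=O)N(c3ccccc3)C2=O)c2ccccc21`: > 100000 nM
compound 3 `Cn1cc(C2=C(c3nn(CCn4ccnc4)c4ncccc34)C(=O)N(c3ccccc3)C2=O)c2ccccc21`: 26400 nM

In a functional assay on K562 cells (Homo sapiens) for antiproliferative activity, read by MTT assay, with a stated time of 48 h (a higher number here means a weaker inhibitor, a lower number a stronger inhibitor), compound 1 reaches only the limit > 100000 nM, so no number is known for it. Compound 2 also sits at the limit > 100000 nM. Compound 3 gives 26400 nM. The step that the two limits leave unreadable from compound 1 to compound 2 stays unreadable because of the limit of > 100000 nM in this assay, at which 2 of the 3 values shown sit. The step of an at least 3.7-fold lower number from compound 2 to compound 3 (0.57 log units; beyond the scatter) concerns an exchange of one azole for another on the chain, not removal of the azole. Compound 4 `Cn1cc(C2=C(c3nn(CCCO)c4ncccc34)C(=O)NC2=O)c2ccccc21` carries the change (hydroxy in place of 1H-1,2,4-triazol-1-yl on a saturated chain carbon, three bonds along the chain from an aromatic nitrogen). Among the measured compounds shown here, no measured step covers this change, and compound 1 offers only a limit as starting point. Compound 4 is therefore expected near the limit, estimated at 100000 nM (range 30000 nM to 300000 nM), a step of a number no higher from compound 1 to compound 4 (the limit leaves the size open) that is expected to stay within scatter.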

Compound 4, half-maximal inhibitory concentration: 85800 nM
Beside the measured number, compound 4's estimate is 1.2-fold (0.07 log units) above it; the measured number falls inside the stated range.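

In this assay, replacing 3-(1H-1,2,4-triazol-1-yl)propyl with 3-hydroxypropyl gives an at least 1.1-fold lower number from compound 1 to compound 4 (0.06 log units; that floor lies within the scatter). With the amide hydrogen kept, compound 4 provides the first readable number, and it shows that this chain position tolerates loss of the azole without a step shown to exceed the scatter. The true size of the step cannot be read: the limit of > 100000 nM in this assay, at which 2 of the 4 values shown sit.

Still open, going by these compounds, is how an amine or a carboxylic acid would read at this place, or a longer chain carrying the hydroxy. Also open, on these data alone, is how 3-hydroxypropyl reads with phenyl on the amide-type nitrogen in a ring.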